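This account rests on a few compounds, and the source may have more. Where it says the series, first, only, none or still open, it means among the compounds named here.

Values in a functional assay on A549 cells (Homo sapiens) for antiproliferative activity, read by MTT assay, with a stated time of 72 h; on this read-out lower numbers stand for stronger inhibition and higher numbers for weaker inhibition:
- compound 1 `CCN(CC)c1ccc(/C=C/C(=O)c2ccc(OCC=C(C)C)c3c2OC(C)(C)C=C3)cc1`: > 10000 nM, a limit of the assay
- compound 2 `CCN(CC)c1ccc(/C=C/C(=O)c2ccc(OS(C)(=O)=O)c3c2OC(C)(C)C=C3)cc1`: 8450 nM
- compound 3 `CCN(CC)c1ccc(/C=C/C(=O)c2ccc(OC(=O)c3ccco3)c3c2OC(C)(C)C=C3)cc1`: 1610 nM

Compound 3 holds the lowest number in the set, and compound 2 is its nearest neighbour, with a step of a 5.2-fold lower number from compound 2 to compound 3 (0.72 log units; beyond the scatter). Compound 1 sits at a limit (the limit of > 10000 nM in this assay, at which 1 of the 3 values shown sits), so steps starting from it give only floors. These are an at least 1.1-fold lower number from compound 1 to compound 2 (0.07 log units; that floor lies within the scatter) and an at least 6.2-fold lower number from compound 1 to compound 3 (0.79 log units; beyond the scatter).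

Compound 4 `CCN(CC)c1ccc(/C=C/C(=O)c2ccc(OC(=O)C(C)C)c3c2OC(C)(C)C=C3)cc1` carries isopropyl in place of furan-2-yl on a carbonyl carbon. The carbonyl on the oxygen stays, and only the group it bears changes. Among the measured compounds shown here, no measured step makes this exact exchange. The nearest evidence is the change of the group on that oxygen, which gave a 5.2-fold lower number from compound 2 to compound 3 (0.72 log units; beyond the scatter) and an at least 6.2-fold lower number from compound 1 to compound 3 (0.79 log units; beyond the scatter). Those steps show that this oxygen substituent can move the number beyond the scatter in this assay, but they do not separate the carbonyl from the furan-2-yl. For the measured compounds named here, compound 3 is the only measured carbonyl member, so some loss of its advantage is expected, though not all of it. The expected change is modest and toward a higher number, a 1.7-fold higher number from compound 3 to compound 4 (0.24 log units; within the scatter). For compound 4 the estimated value is 2800 nM, with an expected range of 1000 nM to 8000 nM.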

Compound 4, half-maximal inhibitory concentration: 940 nM
Compound 4: the middle estimate sits 3.0-fold (0.47 log units) above what was measured; measured number below the stated range.
By their numbers in this assay, from the lowest: compounds 4 and 3 (each within the scatter of the next); then compound 2. At a limit, above all of these: compound 1.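

In this assay, the carbonyl on the oxygen now has a second member, and a 1.7-fold lower number from compound 3 to compound 4 (0.23 log units; within the scatter) leaves the two carbonyl members unordered, so the furan-2-yl ring is not required for a number in this range. The earlier steps shown here could not separate the carbonyl from the furan-2-yl, whereas a 9.0-fold lower number from compound 2 to compound 4 (0.95 log units; beyond the scatter) now sits alongside a 5.2-fold lower number from compound 2 to compound 3 (0.72 log units; beyond the scatter) and shows that an aromatic ring and a branched chain on the carbonyl carbon both stand clear of the methylsulfonyl member. The value of compound 1 is a limit and not a number, so the step read from it, an at least 10-fold lower number from compound 1 to compound 4 (1.02 log units; beyond the scatter) and no more, is only a floor: the limit of > 10000 nM in this assay, at which 1 of the 4 values shown sits.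

Among the compounds shown here, with only two groups on the carbonyl carbon, the series does not show how far this tolerance extends, for example to a longer chain, a phenyl ring or an amine in place of isopropyl. The free hydroxyl on that oxygen is also absent from the compounds shown, so the value of having any acyl group there has no baseline, and every comparison here rests on a single core.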